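Compound 1 to compound 4: isobutyl to cyclobutylmethyl

This account rests on a few compounds, and the source may have more. Where it says the series, first, only, none or still open, it means among the compounds named here.

In a physicochemical assay for lipophilicity, at pH 7.4 (on this read-out higher numbers stand for higher lipophilicity and lower numbers for lower lipophilicity), compound 1 `CCc1ccc(N(CC(C)C)S(=O)(=O)c2ccc3c(c2)C(O)CC(C2CCOCC2)O3)cc1` gives 4.12, the highest of the three numbers in hand. Compound 2 `CCc1ccc(N(CC(C)C)S(=O)(=O)c2ccc3c(c2)C(O)CC(C2CCNCC2)O3)cc1` gives 1.04, and compound 3 `CC(C)CN(c1ccc(C#N)cc1)S(=O)(=O)c1ccc2c(c1)C(O)CC(C1CCOCC1)O2` gives 3.07. Both measured steps are large: a number 3.08 log units lower from compound 1 to compound 2 (beyond the scatter), with piperidin-4-yl in place of oxan-4-yl on a saturated ring carbon, and a number 1.05 log units lower from compound 1 to compound 3 (beyond the scatter), with cyano in place of ethyl on an aromatic carbon.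

Compound 4 `CCc1ccc(N(CC2CCC2)S(=O)(=O)c2ccc3c(c2)C(O)CC(C2CCOCC2)O3)cc1` keeps the core of compound 1 and differs in one place: cyclobutyl in place of isopropyl on a saturated chain carbon bound to a sulfonamide nitrogen. In words, this is cyclobutyl in place of isopropyl on a saturated chain carbon bound to a sulfonamide nitrogen. Cut one bond further out, it reads isobutyl to cyclobutylmethyl.

Neither measured step touches this place, so neither gives a direct size for the change, and their large sizes are not carried over. What leaves and what enters are both of carbon only. The expectation therefore rests on compound 1 at 4.12 and on the structural change alone.

A slight rise in this assay, not beyond the scatter, is expected: a number 0.18 log units higher from compound 1 to compound 4 (within the scatter). Compound 4 is estimated at 4.3, with an expected range from 3.9 to 4.7.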

Compound 4, distribution coefficient: 4.01
Compound 4: middle estimate off by 0.29 log units, on the high side, and the stated range covers the measured number.
By their numbers in this assay, from the lowest: compound 2; then compound 3; then compounds 4 and 1 (each within the scatter of the next).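

In this assay, the saturated chain carbon bound to a sulfonamide nitrogen now has a measured step of its own: a number 0.11 log units lower from compound 1 to compound 4 (within the scatter), with cyclobutyl in place of isopropyl. The two earlier steps, piperidin-4-yl in place of oxan-4-yl and cyano in place of ethyl, lie elsewhere on the molecule and are both beyond the scatter, so they said nothing about this place. Here, one group of carbon only replaces another, with one more heavy atom and a four-membered ring entering, and the read-out does not separate compound 4 from compound 1. The data in hand offer no explanation for this result.

This single exchange leaves open what a group carrying an atom other than carbon would do at this place, such as an amine, a carboxylic acid or an ether, and what a longer chain such as n-hexyl would do. Going by these compounds, it is also open whether cyclobutyl in place of isopropyl would give a step of similar size alongside the cyano of compound 3 or the piperidin-4-yl of compound 2.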